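The source may hold more compounds than are shown below. What is called first, only, known or untested is meant among the compounds shown, and "the series" means these compounds.

Compound 1 `CCCn1cnc2c(N)nc(NCCCc3ccccc3)nc21` and compound 2 `CCCn1c(Br)nc2c(N)nc(NCCCc3ccccc3)nc21` share one core and differ in a single place: bromo in place of hydrogen on an aromatic carbon. In an assay on CHO cells for displacement of a labelled ligand from adenosine receptor A1 (Homo sapiens) (a higher number here means a weaker inhibitor, a lower number a stronger inhibitor), compound 1 gives 3640 nM, and compound 2 gives 583 nM; the step between them is a 6.2-fold lower number from compound 1 to compound 2 (0.80 log units; beyond the scatter). Compound 3 `CCCn1cnc2c(NCCCc3ccccc3)ncnc21` is built on a different core, and the difference between the two cores is not broken down here. In this assay compound 3 gives 18600 nM, the highest number of the three measured. Compound 4 `CCCn1c(Br)nc2c(NCCCc3ccccc3)ncnc21` carries the same kind of change on the core of compound 3: bromo in place of hydrogen on an aromatic carbon. The surroundings of the place read alike for both pairs. The expectation for compound 4 rests on the size of a 6.2-fold lower number from compound 1 to compound 2 (0.80 log units; beyond the scatter), assuming the change carries over to the second core. Compound 4 is therefore expected near 3000 nM, likely between 1200 nM and 9000 nM, which would mean an estimated step of a 6.2-fold lower number from compound 3 to compound 4 (0.79 log units; beyond the scatter).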

Compound 4, inhibition constant: 2670 nM
Compound 4: middle estimate off by 1.1-fold (0.05 log units), on the high side, and the stated range covers the measured number.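

Bromo in place of hydrogen on an aromatic carbon gives a 7.0-fold lower number from compound 3 to compound 4 (0.84 log units; beyond the scatter) in this assay on the core of compound 3. The step carries over from the core of compound 1 to the core of compound 3 with much the same size: the same change on two cores in this assay, a 6.2-fold lower number (0.80 log units; beyond the scatter) from compound 1 to compound 2 and a 7.0-fold lower number (0.84 log units; beyond the scatter) from compound 3 to compound 4, 1.1-fold (0.05 log units) apart, within the scatter of two such steps. This covers one change on two cores in a single assay, so it shows agreement for these two pairs only and gives neither a reason for the step nor any assurance for a further core.

Still open, as far as these compounds go, is whether chloro, iodo or a methyl group at the same place gives a step of like size. Also open, from the compounds shown here alone, is whether the bromo step holds when the propyl group gives way to a longer chain.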